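Replacing the 3-aminocyclohexyl group of compound 3

The compounds below may be only part of what the source reports. "The series", "measured", "known", "first", "only" and "open" are said of these compounds alone.

Compound 3 `CCCCCCCCCCc1ccc(-c2noc([C@@H]3CCC[C@@H](N)C3)n2)cc1` stands lowest of the three numbers: in an assay on HeLa cells for inhibition of sphingosine-1-phosphate transporter SPNS2 (Mus musculus), read by LC-MS, tested at 2 uM (a lower number here means less inhibition, a higher number more inhibition at the concentration tested (going by the name of the read-out)), compound 3 gives 13%. Compound 1 `CCCCCCCCCCc1ccc(-c2noc(CCCCN)n2)cc1` gives 55% and compound 2 `CCCCCCCCCCc1ccc(-c2noc([C@@H]3CCNC3)n2)cc1` gives 62%; the steps of a number 42 percentage points lower from compound 1 to compound 3 (beyond the scatter) and a number 49 percentage points lower from compound 2 to compound 3 (beyond the scatter) show the 3-aminocyclohexyl group well below the other two amine groups, while a number 7 percentage points higher from compound 1 to compound 2 (within the scatter) does not separate those two. Compound 4 `CCCCCCCCCCc1ccc(-c2noc(CC(O)CN3CCCC3)n2)cc1` carries the change (2-hydroxy-3-(pyrrolidin-1-yl)propyl in place of 3-aminocyclohexyl on an aromatic carbon). Among the compounds with values here, no measured step covers this exact group; the two large steps into compound 3 both run against the 3-aminocyclohexyl, so leaving it is expected to raise the number, roughly back towards the open-chain amine of compound 1. The step expected is a number 32 percentage points higher from compound 3 to compound 4 (beyond the scatter). For compound 4 the estimate is 45%, with a range from 20% to 70%.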

Compound 4, a percentage reported as inhibition, at one concentration (the size of the read-out at that concentration, not a potency): 21%
For compound 4 the middle estimate is 24 percentage points above the measured one; the range from low to high includes it.
By their numbers in this assay, from the lowest: compounds 3 and 4 (each within the scatter of the next); then compounds 1 and 2 (each within the scatter of the next).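

In this assay, 2-hydroxy-3-(pyrrolidin-1-yl)propyl in place of 3-aminocyclohexyl gives a number 8 percentage points higher from compound 3 to compound 4 (within the scatter), so leaving the cyclohexyl ring does not by itself restore the number at this position. The same group stands well under both smaller amine groups, with a number 41 percentage points lower from compound 2 to compound 4 (beyond the scatter) and a number 34 percentage points lower from compound 1 to compound 4 (beyond the scatter). Nothing available explains this drop.

Open, as far as these compounds go, is whether the hydroxy group contributes, which a plain 3-(pyrrolidin-1-yl)propyl chain would test. Also open, from the compounds shown here alone, is how a piperidin-4-yl group or a carboxylic acid would read here.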